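The source may hold more compounds than are shown below. What is called first, only, known or untested is meant among the compounds shown, and "the series" means these compounds.

Compound 1 `COc1ccc(-c2nc(C)oc2C(=O)N2CCN(c3cccc(Cl)c3)CC2)cc1` is the starting point, and in a functional assay on HL-60 cells (Homo sapiens) for inhibition, read by MTT assay, with a stated time of 72 h (a higher number here means a weaker inhibitor, a lower number a stronger inhibitor), compound 1 is reported as "not active" (no number reported), with no number attached. Two other compounds were measured beside it. Compound 2 `CCc1nc(-c2ccc(OC)cc2)c(C(=O)N2CCN(c3cccc(Cl)c3)CC2)o1` differs from compound 1 in one place. In this assay compound 2 reaches > 1000 nM, and that is a limit of the assay rather than a number; it is the limit of > 1000 nM in this assay, at which 1 of the 3 values shown sits. Compound 3 `Cc1nc(-c2ccccc2)c(C(=O)N2CCN(c3ccc(Cl)c(Cl)c3)CC2)o1`, which differs in two places, gives 124 nM in this assay. Compound 1 thus stands with the weaker entries, without a number to fix it exactly.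

The unmeasured compound 4 `Cc1nc(-c2ccc(F)cc2)c(C(=O)N2CCN(c3cccc(Cl)c3)CC2)o1` differs from compound 1 in one place: fluoro in place of methoxy on an aromatic carbon. Among the compounds with values here, no measured pair shows this change directly, so the size of the step is open; a move toward stronger inhibition in this assay seems plausible given that compound 3, which also lacks the methoxy, gives 124 nM, though compound 3 differs elsewhere as well. Compound 4 is therefore expected to land near 600 nM, within a range from 100 nM to 3000 nM, with a real chance that only a limit is reported.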

Compound 4, half-maximal inhibitory concentration: 40.1 nM
Estimate against measurement, compound 4: 15-fold (1.18 log units) above; the measured number lies below the stated range.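

In this assay, within the data shown here, compound 1 is recorded as "not active" (no number reported), and compound 4 gives 40.1 nM, so no step between them can be read. Compound 2 offers only a limit, not a number: the limit of > 1000 nM in this assay, at which 1 of the 4 values shown sits.

The compounds shown leave open how far the change from 4-methoxyphenyl to 4-fluorophenyl alone moves inhibition in this assay.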